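From methoxy to trifluoromethyl on compound 3

A few compounds are considered here, and "the series" means these few. Any claim that something is new, unique, unknown or untested is made for them only; others in the source may bear on it.

Values measured in a functional assay on MCF7 cells (Homo sapiens) for antiproliferative activity, with a stated time of 5 days (a lower number here means a stronger inhibitor, a higher number a weaker inhibitor), so far:
compound 1 `CCCCc1ccc2[nH]c(-c3ccc(C(F)(F)F)cc3)c(/C=N/NC(=O)c3ccccc3)c2c1` gives 460 nM
compound 2 `CCCCc1ccc2[nH]c(-c3ccc(C(F)(F)F)cc3)c(/C=N/NC(=O)c3ccc(Cl)cc3)c2c1` gives 1060 nM
compound 3 `CCCCc1ccc2[nH]c(-c3ccc(OC)cc3)c(/C=N/NC(=O)c3ccc(OC)cc3)c2c1` gives 226 nM

Compound 3 has the lowest number of the three, and its gaps to compound 1 and to compound 2 both lie beyond the scatter. One change leads from it to compound 4 `CCCCc1ccc2[nH]c(-c3ccc(C(F)(F)F)cc3)c(/C=N/NC(=O)c3ccc(OC)cc3)c2c1` and is counted as trifluoromethyl in place of methoxy on an aromatic carbon with trifluoromethyl in place of methoxy on an aromatic carbon, para to a large group.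

Among the compounds with values here, no measured step makes this exchange. The only one available, a 2.3-fold higher number from compound 1 to compound 2 (0.36 log units; beyond the scatter) is a different change, chloro in place of hydrogen, so it gives only a rough idea of size. Compound 1 at 460 nM and compound 2 at 1060 nM do carry the 4-(trifluoromethyl)phenyl that compound 4 gains, yet both also differ from compound 3 in a second place. A modest rise in this assay is therefore expected. The expected move is a 2.1-fold higher number from compound 3 to compound 4 (0.33 log units; beyond the scatter) in size. For compound 4 the estimated value is 480 nM with an expected range from 220 nM to 1050 nM in this assay.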

Compound 4, half-maximal inhibitory concentration: 618 nM
Estimate against measurement, compound 4: 1.3-fold (0.11 log units) below; low and high end bracket the measured number.
By their numbers in this assay, from the lowest: compound 3; then compounds 1, 4 and 2 (each within the scatter of the next, the first and the last beyond it).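

In this assay, within the data shown here, replacing 4-methoxyphenyl with 4-(trifluoromethyl)phenyl while the rest of the molecule stays fixed gives a 2.7-fold higher number from compound 3 to compound 4 (0.44 log units; beyond the scatter), the first direct reading of this exchange, and methoxy at this place carries the lower number. With trifluoromethyl held in place, the substituent on the other aromatic ring makes little difference to compound 4: a 1.3-fold higher number from compound 1 to compound 4 (0.13 log units; within the scatter) and a 1.7-fold lower number from compound 2 to compound 4 (0.23 log units; within the scatter) both stay within the scatter. Nothing available accounts for the rise on leaving methoxy.

Whether the exchange has the same size with hydrogen or chloro on the other aromatic ring remains open, as only one such pair is shown. On these data alone, how an amine or a carboxylic acid at this place would compare with methoxy and trifluoromethyl is also open.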